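The compounds below may be only part of what the source reports. "The series", "measured", "known", "first", "only" and "open" are said of these compounds alone.

Measured compounds: compound 1 `O=C(/C=C/c1ccc(Cl)cc1)C[C@@H]1O[C@H](CO)[C@@H](O)[C@H](O)[C@H]1O` with -5.97%, compound 2 `CCOC(=O)C(C(=O)OCC)C(CC(=O)C[C@@H]1O[C@H](CO)[C@@H](O)[C@H](O)[C@H]1O)c1ccc2ccccc2c1` with -20%, and compound 3 `O=C(/C=C/c1cccnc1)C[C@@H]1O[C@H](CO)[C@@H](O)[C@H](O)[C@H]1O` with -35.4%, all in an assay on isolated protein for inhibition of lysosomal alpha-glucosidase (Rattus norvegicus), tested at 100 uM; on this read-out lower numbers stand for less inhibition and higher numbers for more inhibition at the one concentration tested (going by the name of the read-out).

On these numbers compound 2 stands second highest of the three, a number beyond the scatter above compound 3 and beyond the scatter below compound 1. Compound 4 `CCOC(=O)C(C(=O)OCC)C(CC(=O)C[C@@H]1O[C@H](CO)[C@@H](O)[C@H](O)[C@H]1O)c1ccccc1` differs from compound 2 in one place: phenyl in place of naphthalen-2-yl on a saturated chain carbon bound to two saturated chain carbons. Within the data shown here, the only measured step, a number 29.4 percentage points lower from compound 1 to compound 3 (beyond the scatter), exchanges one aromatic group for another on a different part of the chain and does not bear directly on a change in ring count; there is no measured pair that does. The expected step of a number 5 percentage points higher from compound 2 to compound 4 (within the scatter) is therefore none beyond the scatter. Compound 4 is estimated at -15%, between -40% and 10%.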

Compound 4, a percentage reported as inhibition, at one concentration (the size of the read-out at that concentration, not a potency): -45%
Compound 4: middle estimate off by 30 percentage points, on the high side; measured number below the stated range.
By their numbers in this assay, from the lowest: compounds 4 and 3 (each within the scatter of the next); then compound 2; then compound 1.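

In this assay, the change at this saturated chain carbon bound to two saturated chain carbons gives a number 25 percentage points lower from compound 2 to compound 4 (beyond the scatter), so the read-out responds to which aromatic group sits at this position, something the earlier step, made elsewhere on the chain, could not show. The groups exchanged differ in their aromatic rings and heavy atoms, and neither carries hydrogen-bond donors or acceptors. No accompanying measurement explains the direction of this step.

The compounds shown leave open whether the number follows aromatic ring count alone. Cyclohexyl or an amine at this position would help to separate these possibilities.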